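Triazole Phthalimides: Three Inactive Limits and a Fourth Analogue

The compounds below may be only part of what the source reports. "The series", "measured", "known", "first", "only" and "open" are said of these compounds alone.

Measured compounds:
compound 1, `C#CCSc1nnc(CC)n1N1C(=O)c2ccccc2C1=O`, > 200000 nM
compound 2, `CCc1nnc(SCC(=O)c2ccc(C)cc2)n1N1C(=O)c2ccccc2C1=O`, > 200000 nM
compound 3, `CCCc1nnc(SCC(=O)c2ccc(C)cc2)n1N1C(=O)c2ccccc2C1=O`, > 200000 nM

In a functional assay on HepG2 cells (Homo sapiens) for cytotoxicity, read by MTT assay, with a stated time of 48 h (on this read-out lower numbers stand for stronger inhibition and higher numbers for weaker inhibition), compound 1 is recorded only as a limit of the assay, > 200000 nM. Compound 2 likewise reaches only a limit, > 200000 nM. Compound 3 too gives only a limit, > 200000 nM. All three sit at the limit of > 200000 nM in this assay, at which 3 of the 3 values shown sit, so no number is known for any of them.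

Compound 2 and compound 1 differ by ethynyl in place of (4-methylphenyl)carbonyl on a saturated chain carbon bound to a sulfur; the step that the two limits leave unreadable from compound 2 to compound 1. Compound 2 and compound 3 differ in their cores by methyl in place of hydrogen on a saturated chain carbon, two bonds along the chain from an aromatic carbon; the step that the two limits leave unreadable from compound 2 to compound 3.

Compound 4, `C#CCSc1nnc(CCC)n1N1C(=O)c2ccccc2C1=O`, is not yet measured. It differs from compound 3 by ethynyl in place of (4-methylphenyl)carbonyl on a saturated chain carbon bound to a sulfur, the same change as from compound 2 to compound 1, made at the same place. Since the earlier step could not be read from two limits, the step for compound 4 in this assay is expected to be a number no higher from compound 3 to compound 4 (the limit leaves the size open), resting only on the three limits recorded. Compound 4 is therefore estimated at 200000 nM, most likely again reported as a limit rather than a number.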

Compound 4, half-maximal inhibitory concentration: > 200000 nM
Compound 4 was reported as a limit; the forecaster's own chance of this, stated with the estimate: 80%; the middle value sits exactly at the limit.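

In this assay, going by these compounds alone, compound 4 gives only a limit, so its steps from compound 3 and from compound 1 cannot be read, and no new step emerges. The compounds shown leave open whether the ethynyl and (4-methylphenyl)carbonyl groups, or the added methyl, change the cytotoxicity at all, with no number for any compound.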